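Extending a Saturated Chain: What to Expect for Compound 4

The source may report more compounds than this note shows. Statements on the series, on what has been measured and on what is new or still open speak of the compounds shown alone.

Three compounds have been measured in a functional assay on FL5.12 cells (Mus musculus) for cytotoxicity, read by flow cytometry, with a stated time of 48 h; a higher number here means a weaker inhibitor, a lower number a stronger inhibitor:
compound 1, `CCCC/C=C/c1ccc(CO[C@@H]2CN[C@@H](CO)C2)cc1`, gives 5500 nM;
compound 2, `CCCCCC/C=C/c1ccc(CO[C@@H]2CN[C@@H](CO)C2)cc1`, gives 1400 nM;
compound 3, `CCCCCCCCCCCCc1ccc(CO[C@H]2CN[C@H](CO)C2)cc1`, gives 3900 nM.

Compound 1 and compound 2 share one core and differ in a single place, (ethyl in place of hydrogen on a saturated chain carbon, four bonds along the chain from a double-bonded chain carbon). That change produced a 3.9-fold lower number from compound 1 to compound 2 (0.59 log units; beyond the scatter). Compound 3 has a different core; the difference between the two cores is not broken down here. The values of compound 3 and compound 1 lie within the usual scatter of each other, whereas compound 2 gives a lower number than compound 3 by more than the scatter.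

Compound 4, `CCCCCCCCCCCCCCc1ccc(CO[C@H]2CN[C@H](CO)C2)cc1`, has not been measured. It differs from compound 3 by ethyl in place of hydrogen on a saturated chain carbon, ten or more bonds along the chain from an aromatic carbon. Among the measured compounds shown here, this is the same kind of change as the one made from compound 1 to compound 2, but the place differs: there the ethyl entered on a saturated chain carbon four bonds along the chain from a double-bonded chain carbon, here on a saturated chain carbon reckoned along the chain from an aromatic carbon, as just described for compound 4. For the measured compounds named here, the expectation for compound 4 rests on the single earlier step of a 3.9-fold lower number from compound 1 to compound 2 (0.59 log units; beyond the scatter), tempered by the different place and core. Compound 4 is therefore expected to show a 2.0-fold lower number from compound 3 to compound 4 (0.29 log units; within the scatter). In this assay compound 4 is estimated at 2000 nM, most likely between 800 nM and 5000 nM.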

Compound 4, half-maximal inhibitory concentration: 5700 nM
Compound 4: the middle estimate sits 2.9-fold (0.45 log units) below what was measured, outside the stated range (above it).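

In this assay, the ethyl gave a 1.5-fold higher number from compound 3 to compound 4 (0.16 log units; within the scatter), a step that cannot be told apart from the differences seen between repeated measurements. Placed beside the earlier step, this shows that the gain seen on the core of compound 1 did not carry over to the core of compound 3: the same change on two cores in this assay, a 3.9-fold lower number (0.59 log units; beyond the scatter) from compound 1 to compound 2 and a 1.5-fold higher number (0.16 log units; within the scatter) from compound 3 to compound 4, 5.7-fold (0.76 log units) apart, beyond the scatter of two such steps. Among the compounds shown here, it does not show what lies behind the gap, since each core offers only one such pair, and the two pairs differ in their core, in the place of the change and in the chain that receives the ethyl.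

The compounds shown leave open whether the same chain would read alike on both cores, as no chain appears on both. They also leave open how a much shorter chain such as hexyl, or a long chain ending in an amine or a carboxylic acid, would read in this assay.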